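This account rests on a few compounds, and the source may have more. Where it says the series, first, only, none or still open, it means among the compounds named here.

Among the compounds with values here, compound 2 `CC(C)Oc1ccccc1-c1ncc(C(=O)O)c(=O)[nH]1` in a functional assay on the whole organism (strain Sprague-Dawley) for inhibition, with Rattus norvegicus as the target, with a stated time of 10 min (a higher number here means that more compound is needed for the effect, a lower number that less compound is needed), gives 0.8 mg/kg and stands lowest of the two numbers measured so far, though within the scatter of compound 1 `CCCOc1ccccc1-c1ncc(C(=O)O)c(=O)[nH]1`, which in this assay gives 0.9 mg/kg. Within the data shown here, the one measured step, a 1.1-fold lower number from compound 1 to compound 2 (0.05 log units; within the scatter), swaps one alkyl on the aromatic oxygen for another and stays within the scatter. Compound 3 `C[S+]([O-])c1ccccc1-c1ncc(C(=O)O)c(=O)[nH]1` is not yet measured; it differs from compound 2 in a group of 3 heavy atoms (1 carbon, 1 oxygen, 1 sulfur; no ring) in place of a group of 4 heavy atoms (3 carbon, 1 oxygen; no ring), on an aromatic carbon: the isopropoxy leaves and a group of carbon, oxygen and sulfur enters, on the aromatic carbon ortho to a large group. The earlier step bears on this only loosely, as it kept the alkoxy in place. Among the measured compounds shown here, no measured pair shows how such a sulfur-bearing group behaves here, so a modest loss with a wide range is expected for compound 3 in this assay, estimated at 1.6 mg/kg, between 0.4 mg/kg and 6 mg/kg. The expected step is a 2.0-fold higher number from compound 2 to compound 3 (0.30 log units; within the scatter).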

Compound 3, dose for 50% inhibition: > 5 mg/kg
Compound 3 gave a limit, no number (the forecaster's own chance of this, stated with the estimate: 10%); at least 3.1-fold (0.49 log units) between middle value and limit.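

The reading of compound 3 in this assay is a limit and not a number: the limit of > 5 mg/kg in this assay, at which 1 of the 3 values shown sits. The earlier step changed only the alkyl on the oxygen and stayed within the scatter, whereas replacing the whole group on the aromatic carbon ortho to a large group gives an at least 6.2-fold higher number from compound 2 to compound 3 (0.79 log units; beyond the scatter), and likewise an at least 5.5-fold higher number from compound 1 to compound 3 (0.74 log units; beyond the scatter). This position therefore responds to the change of group, and the size of the loss has only a lower bound.

The three compounds do not separate the loss of the ether oxygen from the entry of the sulfur-bearing group, so no cause can be assigned. From the compounds shown here alone, how an amine, a carboxylic acid or a longer alkoxy chain on this carbon would read in this assay remains open.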